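The source may hold more compounds than are shown below. What is called first, only, known or untested is meant among the compounds shown, and "the series" means these compounds.

Compound 1 `O=C(O)c1cccc(S(=O)(=O)N2CCC(NS(=O)(=O)c3cc(S(=O)(=O)c4ccccc4)ccc3C(F)(F)F)CC2)c1` gives 12500 nM in a physicochemical assay for solubility; a lower number here means a less soluble compound, a higher number a more soluble compound.
Compound 2 `O=C(O)c1ccc(N2CCC(NS(=O)(=O)c3cc(S(=O)(=O)c4ccccc4)ccc3C(F)(F)F)CC2)cc1` gives 25000 nM in this assay.
Compound 3 `O=C(O)CCCC(=O)N1CCC(NS(=O)(=O)c2cc(S(=O)(=O)c3ccccc3)ccc2C(F)(F)F)CC1` gives 50000 nM in this assay.

Compound 1 stands lowest of these three numbers in this assay. Its nearest neighbour is compound 2, reached by a 2.0-fold higher number from compound 1 to compound 2 (0.30 log units; within the scatter); its furthest is compound 3, reached by a 4.0-fold higher number from compound 1 to compound 3 (0.60 log units; beyond the scatter). Between the other two there is a 2.0-fold higher number from compound 2 to compound 3 (0.30 log units; within the scatter).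

Compound 4 `O=C(CC1CCNCC1)N1CCC(NS(=O)(=O)c2cc(S(=O)(=O)c3ccccc3)ccc2C(F)(F)F)CC1` differs from compound 1 in one place: ((piperidin-4-yl)methyl)carbonyl in place of (3-carboxyphenyl)sulfonyl on an amine nitrogen in a ring. Going by the values given here, no measured step makes this exact change, and each of the three measured compounds carries a carboxy group in the varied position, which compound 4 does not. The step that bears most closely is the one in which (3-carboxypropyl)carbonyl replaced the same (3-carboxyphenyl)sulfonyl, giving a 4.0-fold higher number from compound 1 to compound 3 (0.60 log units; beyond the scatter); the step to 4-carboxyphenyl, which keeps an aromatic ring, gave only a 2.0-fold higher number from compound 1 to compound 2 (0.30 log units; within the scatter). Since compound 4 likewise carries a carbonyl-linked non-aromatic group on that ring nitrogen, a step of about the size seen toward compound 3, in the same upward direction, is expected: a 4.0-fold higher number from compound 1 to compound 4 (0.60 log units; beyond the scatter). Compound 4 is therefore estimated to give 50000 nM in this assay, with a range from 15000 nM to 150000 nM.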

Compound 4, solubility: 100000 nM
For compound 4 the middle estimate is 2.0-fold (0.30 log units) below the measured one; the measured number falls inside the stated range.
By their numbers in this assay, from the lowest: compounds 1, 2, 3 and 4 (each within the scatter of the next, the first and the last beyond it).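

At the amine nitrogen in the ring, ((piperidin-4-yl)methyl)carbonyl in place of (3-carboxyphenyl)sulfonyl gives the largest step yet seen from compound 1 in this assay (an 8.0-fold higher number from compound 1 to compound 4 (0.90 log units; beyond the scatter)), and the same group in place of 4-carboxyphenyl also gives a step beyond the scatter (a 4.0-fold higher number from compound 2 to compound 4 (0.60 log units; beyond the scatter)). Going by these compounds alone, compound 4 thus shows for the first time that a group without a carboxy group can stand at this position and still reach the top of this set, for the step between the two carbonyl-linked compounds, piperidin-4-yl in place of 2-carboxyethyl, stays within the scatter (a 2.0-fold higher number from compound 3 to compound 4 (0.30 log units; within the scatter)) and leaves compound 3 and compound 4 unresolved. No measurement offered here accounts for any of these steps.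

On these data alone, the step from compound 1 to compound 4 exchanges the sulfonyl link, the aromatic ring and the carboxylic acid all at once, so the share of each stays unknown, and a benzoyl group or an aryl sulfonyl group without the carboxylic acid would be needed to divide it. As far as these compounds go, it also stays open what the ring nitrogen of piperidin-4-yl contributes, which a tetrahydropyran-4-yl ring or an N-methylpiperidin-4-yl ring in its place could test.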